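Trifluoromethyl for carbamoyl on the sulfonamide-bearing ring

The compounds below may be only part of what the source reports. "The series", "measured", "known", "first", "only" and "open" are said of these compounds alone.

Of the compounds shown here, three have been measured so far in an assay on isolated protein for inhibition of alkaline phosphatase, tissue-nonspecific isozyme (Homo sapiens); a lower number here means a stronger inhibitor, a higher number a weaker inhibitor. Going by the values given here, compound 1 `CNC(=O)c1cncc(NS(=O)(=O)c2cc(Cl)ccc2OC)c1` gives 109 nM, and compound 2 `COc1ccc(Cl)cc1S(=O)(=O)Nc1cncc(C(N)=O)c1` gives 16 nM; the one measured step between them, a 6.8-fold lower number from compound 1 to compound 2 (0.83 log units; beyond the scatter), is a change on the amide nitrogen. Compound 3 `COc1ccc(C(N)=O)cc1S(=O)(=O)Nc1cccnc1` gives 1490 nM, the highest of the three numbers: it lies well above compound 1 and much further above compound 2, both gaps beyond the scatter.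

Compound 4 `COc1ccc(C(F)(F)F)cc1S(=O)(=O)Nc1cccnc1` differs from compound 3 by trifluoromethyl in place of carbamoyl on an aromatic carbon. Among the compounds with values here, no measured step touches this position or this exchange; the only measured step, from compound 1 to compound 2, alters the amide group rather than removing it, and the two stronger compounds carry a chloro group where compound 3 carries the carbamoyl, but they also differ on the other ring, so no single-step comparison is available. The expectation therefore leans on the observation that the carbamoyl-bearing compound 3 sits at the weak end of the set. Compound 4 is expected to give 350 nM, between 70 nM and 1800 nM, which would mean an estimated step of a 4.3-fold lower number from compound 3 to compound 4 (0.63 log units; beyond the scatter) in this assay, with wide uncertainty.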

Compound 4, half-maximal inhibitory concentration: 183 nM
Compound 4: middle estimate off by 1.9-fold (0.28 log units), on the high side; low and high end bracket the measured number.
By their numbers in this assay, from the lowest: compound 2; then compounds 1 and 4 (each within the scatter of the next); then compound 3.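

In this assay, going by these compounds alone, the exchange of carbamoyl for trifluoromethyl gives an 8.1-fold lower number from compound 3 to compound 4 (0.91 log units; beyond the scatter) and is the first direct reading at this place, the aromatic carbon para to a methoxy group. It shows that carbamoyl, with its hydrogen-bond donor and hydrogen-bond acceptor, is not required there for a lower number, and that a group with neither can take its place on the core of compound 3; the earlier step, a 6.8-fold lower number from compound 1 to compound 2 (0.83 log units; beyond the scatter), concerned an amide-type nitrogen elsewhere and could not show this. Nothing given here accounts for the size of this step.

On these data alone, with only these two groups read at this place on this core, it stays open whether a nitrile, a carboxylic acid, an amine or a plain hydrogen would fall nearer to carbamoyl or to trifluoromethyl, so no trend across groups can yet be drawn. As far as these compounds go, it is also open whether the same exchange would give a step of similar size on a different core, such as that of compound 2, which differs from compound 3 in more than one place.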